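Swapping the Amide Cap on Compound 3

The source may hold more compounds than are shown below. What is called first, only, known or untested is meant among the compounds shown, and "the series" means these compounds.

Of the compounds shown here, three have so far been measured in a functional assay on NFF cells (Homo sapiens) for antiproliferative activity; on this read-out higher numbers stand for weaker inhibition and lower numbers for stronger inhibition. Compound 1 `CN(C)c1ccc(NC(=O)[C@H](CCCCCC(=O)NO)NC(=O)c2ccc(C(F)(F)F)cc2)cc1` gives 400 nM. Compound 2 `CN(C)c1ccc(C(=O)N[C@@H](CCCCCC(=O)NO)C(=O)Nc2cccc3cccnc23)cc1` gives 570 nM. Compound 3 `O=C(/C=C/c1ccccc1)N[C@@H](CCCCCC(=O)NO)C(=O)Nc1cccc2cccnc12` gives 1240 nM, the highest of the three numbers; compound 2 stands nearest to it and compound 1 furthest. For the measured compounds named here, the only single-point step among the measured compounds is a 2.2-fold higher number from compound 2 to compound 3 (0.34 log units; beyond the scatter), which moves toward weaker inhibition.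

Compound 4 `O=C(CCCCC[C@H](NC(=O)c1ccc(C(F)(F)F)cc1)C(=O)Nc1cccc2cccnc12)NO` has not yet been measured. It differs from compound 3 in one place: 4-(trifluoromethyl)phenyl in place of 2-phenylethenyl on a carbonyl carbon. Going by the values given here, no measured pair reproduces this exact change. The step of a 2.2-fold higher number from compound 2 to compound 3 (0.34 log units; beyond the scatter) shows that exchanging the group on this carbonyl carbon can shift the number by a modest amount beyond the scatter. Compound 1 carries the same 4-(trifluoromethyl)phenyl group that enters here, but it differs from compound 2 in more than one place, so only their two values can be set side by side: compound 1 gives 400 nM while compound 2 gives 570 nM, two numbers that lie within the scatter of each other.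

On that basis compound 4 is expected to return to a number near those of compounds 1 and 2. Compound 4 is therefore estimated at 520 nM, with a range of 250 nM to 1100 nM. The expected step is a 2.4-fold lower number from compound 3 to compound 4 (0.38 log units; beyond the scatter), toward stronger inhibition.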

Compound 4, half-maximal inhibitory concentration: 696 nM
The estimate for compound 4 lay 1.3-fold (0.13 log units) below the measured number, within the range that was stated.
By their numbers in this assay, from the lowest: compounds 1, 2, 4 and 3 (each within the scatter of the next, the first and the last beyond it).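

In this assay the carbonyl carbon bearing the amide-type nitrogen now carries a third group, and 4-(trifluoromethyl)phenyl in place of 2-phenylethenyl gives a 1.8-fold lower number from compound 3 to compound 4 (0.25 log units; within the scatter) and so, unlike the earlier exchange of 4-(dimethylamino)phenyl for 2-phenylethenyl, this change does not clear the scatter. The two para-free readings of the same phenyl group can also now be compared directly: trifluoromethyl in place of dimethylamino on an aromatic carbon gives a 1.2-fold higher number from compound 2 to compound 4 (0.09 log units; within the scatter) and the two groups cannot be told apart on this read-out. For the compounds shown here, the other end of the molecule, which the earlier compounds could only set side by side, can also be read in a single step, as quinolin-8-yl in place of 4-(dimethylamino)phenyl on an amide-type nitrogen gives a 1.7-fold higher number from compound 1 to compound 4 (0.24 log units; within the scatter) and leaves that exchange unresolved as well.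

Nothing available here accounts for these numbers. Still open, on these data alone, is whether the flat response at this carbonyl carbon would hold for a group without a ring, such as methyl or a cyclohexylmethyl chain, or for a phenyl group carrying a carboxylic acid or a primary amine.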